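Isopropyl in place of oxan-4-yl on compound 3

The source may hold more compounds than are shown below. What is called first, only, known or untested is meant among the compounds shown, and "the series" means these compounds.

In a functional assay on PC-3 cells (Homo sapiens) for inhibition, with a stated time of 72 h (on this read-out lower numbers stand for stronger inhibition and higher numbers for weaker inhibition), compound 1 (`Cc1nc(-c2nc[nH]n2)ccc1-c1cnc2c(n1)N(CC1CCOCC1)C(=O)CN2`) gives 82 nM, compound 2 (`CO[C@H]1CC[C@@H](CN2C(=O)CNc3ncc(-c4ccc(-c5nc[nH]n5)nc4C)nc32)CC1`) gives 24 nM and compound 3 (`Cc1nc(-c2nc[nH]n2)ccc1-c1cnc2c(n1)N(C1CCOCC1)C(=O)CN2`) gives 102 nM. Compound 3 sits at the weak end of this short series together with compound 1, and the two are not separated: a 1.2-fold higher number from compound 1 to compound 3 (0.09 log units; within the scatter). Compound 2 stands clear of compound 3: a 4.3-fold higher number from compound 2 to compound 3 (0.63 log units; beyond the scatter).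

Compound 4 (`Cc1nc(-c2nc[nH]n2)ccc1-c1cnc2c(n1)N(C(C)C)C(=O)CN2`) has isopropyl in place of oxan-4-yl on an amide-type nitrogen in a ring. All three measured steps change the group on this nitrogen. Apart from a 1.2-fold higher number from compound 1 to compound 3 (0.09 log units; within the scatter), the other two are modest: a 3.4-fold lower number from compound 1 to compound 2 (0.53 log units; beyond the scatter) and a 4.3-fold higher number from compound 2 to compound 3 (0.63 log units; beyond the scatter). None of the three compounds carries an open-chain group there, so the evidence for this change is indirect. The largest measured change at this nitrogen is modest, and the step that only shortens the attachment stays within the scatter. On that basis, no large shift is expected in this assay, and a step beyond the scatter in either direction cannot be ruled out. The expected step is small: a 1.2-fold higher number from compound 3 to compound 4 (0.07 log units; within the scatter). For compound 4 the estimated value is 120 nM, with an expected range of 50 nM to 290 nM.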

Compound 4, half-maximal inhibitory concentration: 149 nM
Beside the measured number, compound 4's estimate is 1.2-fold (0.09 log units) below it; the measured number falls inside the stated range.
By their numbers in this assay, from the lowest: compound 2; then compounds 1, 3 and 4 (each within the scatter of the next).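

Isopropyl is the first open-chain group on this amide-type nitrogen, and in this assay the ring of the earlier groups proves dispensable at this level of inhibition: replacing oxan-4-yl leaves a 1.5-fold higher number from compound 3 to compound 4 (0.16 log units; within the scatter), and replacing (oxan-4-yl)methyl leaves a 1.8-fold higher number from compound 1 to compound 4 (0.26 log units; within the scatter). Within the data shown here, removing the six-membered ring and its oxygen therefore does not separate compound 4 from compound 1 or compound 3, whereas (4-methoxycyclohexyl)methyl remains the one group here that stands apart, with a 6.2-fold higher number from compound 2 to compound 4 (0.79 log units; beyond the scatter). No measurement available here explains these steps.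

The compounds shown leave open which part of the (4-methoxycyclohexyl)methyl group carries the difference seen for compound 2, a question that cyclohexylmethyl or 4-methoxycyclohexyl on the same nitrogen would address. Also open, on these data alone, is how this position responds to a longer open chain such as n-butyl, or to an amine or a carboxylic acid on the cyclohexyl ring in place of the methoxy group.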